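The compounds below may be only part of what the source reports. "The series", "measured", "known", "first", "only" and "open" are said of these compounds alone.

Measured so far in a functional assay on the whole organism for agonist activity, with Mus musculus as the target; a lower number here means that less compound is needed, a higher number that more compound is needed for the effect:
- compound 1 `CC(C#CCn1ccnc1)N1CCCC1=O`: > 100 mg/kg, a limit
- compound 2 `Cc1cncn1CC#CC(C)N1CCCC1=O`: > 100 mg/kg, a limit

Compound 1 is known only through its limit of > 100 mg/kg. The evidence so far consists of the limit of > 100 mg/kg in this assay, at which 2 of the 2 values shown sit.

Compound 3 `CC(C#CCN(C)C)N1CCCC1=O` carries dimethylamino in place of 1H-imidazol-1-yl on a saturated chain carbon bound to a triple-bonded carbon.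

Among the compounds with values here, the only measured step is a step that the two limits leave unreadable from compound 1 to compound 2, and it supplies no size for this change. With nothing firmer to go on, a step towards a lower dose in this assay is tentatively expected, estimated as an at least 33-fold lower number from compound 1 to compound 3 (1.52 log units; beyond the scatter). For compound 3 the estimate is 3 mg/kg, with an expected range of 0.3 mg/kg to 60 mg/kg.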

Compound 3, dose for half-maximal effect: 100 mg/kg
Compound 3: middle estimate off by 33-fold (1.52 log units), on the low side, and the stated range ends below it.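

In this assay compound 3 gives 100 mg/kg, the first actual dose in this short series, and dimethylamino in place of 1H-imidazol-1-yl on a saturated chain carbon bound to a triple-bonded carbon gives a number no higher from compound 1 to compound 3 (the limit leaves the size open). Compound 1 stands at > 100 mg/kg, which is a limit, so the size of the step to compound 3 cannot be read. The values still sit together at one end of the scale: the limit of > 100 mg/kg in this assay, at which 2 of the 3 values shown sit.

On these data alone, whether diethylamino or piperidin-1-yl at this place would give a lower dose remains open.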